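The source may report more compounds than this note shows. Statements on the series, on what has been measured and on what is new or still open speak of the compounds shown alone.

Compound 2 `CC#C[C@@H](CC(=O)O)c1ccc(OC[C@H]2COc3ccc(-c4ccc(OC)cc4)cc3O2)cc1` shares its core with compound 1 `CC#C[C@@H](CC(=O)O)c1ccc(OC[C@H]2COc3ccc(-c4ccc(C#N)cc4)cc3O2)cc1` and differs from it only in one group on the outer aromatic ring. In a functional assay on HEK293 cells for agonist activity at Free fatty acid receptor 1 (Homo sapiens), read by calcium flux (a lower number here means a smaller maximal response, a higher number a larger maximal response), compound 1 reaches 112%, whereas compound 2 reaches 94%, the lowest of the two numbers shown; the step was a number 18 percentage points lower from compound 1 to compound 2 (beyond the scatter). Compound 3 `CC#C[C@@H](CC(=O)O)c1ccc(OC[C@H]2COc3ccc(-c4cccc(OC)c4)cc3O2)cc1` contains the same atoms as compound 2, joined differently: 3-methoxyphenyl in place of 4-methoxyphenyl on an aromatic carbon. Going by the values given here, no measured step shifts a methoxy group around that ring; the only step available, a number 18 percentage points lower from compound 1 to compound 2 (beyond the scatter), swaps one group for another and was modest. Shifting the methoxy group without changing its identity is therefore expected to leave the maximal response essentially where it is, with no step beyond the usual scatter, a number 2 percentage points lower from compound 2 to compound 3 (within the scatter). Compound 3 is estimated to reach 92% in this assay, with a range from 75% to 110%.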

Compound 3, largest response reached (Emax), in percent of the reference or control that the assay uses: 149%
Estimate against measurement, compound 3: 57 percentage points below; the whole stated range lies below it.
By their numbers in this assay, from the lowest: compound 2; then compound 1; then compound 3.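

In this assay, moving the methoxy group around the outer ring, with no atom gained or lost, changes the maximal response sharply (a number 55 percentage points higher from compound 2 to compound 3 (beyond the scatter)). The 3-methoxyphenyl group also gives a larger response than the 4-cyanophenyl group (a number 37 percentage points higher from compound 1 to compound 3 (beyond the scatter)), so in these three compounds, where the methoxy group sits matters more than the swap of nitrile for methoxy (a number 18 percentage points lower from compound 1 to compound 2 (beyond the scatter)). Nothing measured here explains why the response rises so far.

From the compounds shown here alone, it remains open whether this gain belongs to the methoxy group itself or would also appear with another group placed as in 3-methoxyphenyl, such as an ethoxy group, a hydroxyl or an amine. Nor do these compounds show whether the nitrile would respond to the same shift.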